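A benzylamine for a diaryl ether on the shared core

A few compounds are considered here, and "the series" means these few. Any claim that something is new, unique, unknown or untested is made for them only; others in the source may bear on it.

Compound 1 `Nc1cc(N)c2nc(-c3ccccc3)c(Oc3ccc(Cl)c(Cl)c3)nc2c1` has been measured in a functional assay on RPMI8266 cells (Homo sapiens) for inhibition, read by sulforhodamine B assay, with a stated time of 48 h (on this read-out lower numbers stand for stronger inhibition of growth and higher numbers for weaker inhibition of growth), where compound 1 gives < 100000 nM, which is a limit of the assay and not a number. Compound 2 `CCOC(=O)[C@H](CCC(=O)O)NC(=O)c1ccc(CNc2nc3cc(N)cc(N)c3nc2-c2ccccc2)cc1` gives < 100000 nM in this assay, again only a limit. Compound 3 `CCOC(=O)[C@H](CCC(=O)O)NC(=O)c1ccc(Oc2nc3cc(N)cc(N)c3nc2-c2ccccc2)cc1` gives < 100000 nM in this assay, also a limit. What is known is therefore (the limit of < 100000 nM in this assay, at which 3 of the 3 values shown sit), and compound 1 stands at that limit with no number of its own. Compound 4 `Nc1cc(N)c2nc(-c3ccccc3)c(NCc3ccc(F)cc3)nc2c1` carries (4-fluorobenzyl)amino in place of 3,4-dichlorophenoxy on an aromatic carbon. Going by the values given here, with no step between measured compounds to draw on, the expected step from compound 1 to compound 4 is a step that the limit leaves unreadable from compound 1 to compound 4, with no direction preferred beyond the scatter. Compound 4 is expected to give 30000 nM in this assay, within 5000 nM to 100000 nM.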

Compound 4, concentration for total growth inhibition: 6310 nM
The estimate for compound 4 lay 4.8-fold (0.68 log units) above the measured number; low and high end bracket the measured number.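

Going by these compounds alone, compound 1 has only a limit, so no step from it to compound 4 can be read: the limit of < 100000 nM in this assay, at which 3 of the 4 values shown sit.
The compounds shown leave open how (4-fluorobenzyl)amino and 3,4-dichlorophenoxy on the shared core compare in this assay as measured numbers.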